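Methoxy to hydroxy on compound 1

A few compounds are considered here, and "the series" means these few. Any claim that something is new, unique, unknown or untested is made for them only; others in the source may bear on it.

Measured in a functional assay on Huh-7 cells (Homo sapiens) for cytotoxicity, with a stated time of 48 h; a lower number here means a stronger inhibitor, a higher number a weaker inhibitor:
- compound 1 `COc1cc(OC)c(C(=O)/C=C/c2ccccc2OC)c(OC)c1`: 9800 nM
- compound 2 `COc1cc(OC)c(C(=O)/C=C/c2ccccc2SC)c(OC)c1`: 14100 nM

Within the data shown here, compound 1 stands level with the only other measured compound: a 1.4-fold higher number from compound 1 to compound 2 (0.16 log units; within the scatter). Compound 3 `COc1cc(O)c(C(=O)/C=C/c2ccccc2OC)c(OC)c1` differs from compound 1 by hydrogen in place of methyl on an oxygen on an aromatic ring, that is, methoxy to hydroxy. Among the measured compounds shown here, no measured step shows this change. The closest one, a 1.4-fold higher number from compound 1 to compound 2 (0.16 log units; within the scatter), also replaces a methoxy, but with methylsulfanyl, so it offers only a loose guide. No shift beyond the scatter is therefore expected in this assay, and the expected step is a 1.2-fold lower number from compound 1 to compound 3 (0.09 log units; within the scatter). For compound 3 the estimated value is 8000 nM, with an expected range of 3000 nM to 20000 nM.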

Compound 3, half-maximal inhibitory concentration: > 20000 nM
Compound 3 ended at the assay's limit; the forecaster's own chance of this, stated with the estimate: 5%; middle value at least 2.5-fold (0.39 log units) from the limit.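

In this assay, compound 3 gives only a limit, > 20000 nM, and not a number. The step is therefore a floor: an at least 2.0-fold higher number from compound 1 to compound 3 (0.30 log units; that floor lies within the scatter). Hydrogen in place of methyl on this oxygen gives no sign of a stronger inhibitor, which the earlier step, made at a different methoxy group, could not show, yet this floor alone does not establish a real loss. The compounds shown leave open how large the true step is, and whether an amine or a longer chain such as ethoxy in this place would match compound 1.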